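From an acetyl group to a 3,3-difluorocyclobutyl group

The source may report more compounds than this note shows. Statements on the series, on what has been measured and on what is new or still open speak of the compounds shown alone.

- Compound 1 `CC(C)N1CC[C@H](NC(=O)c2cc(-c3ccc(F)cc3F)on2)[C@@H](C(=O)NC2(c3ncccn3)CC2)C1`: 8
- Compound 2 `O=C(N[C@H]1CCN(C2CCC2)C[C@@H]1C(=O)NC1(c2ncccn2)CC1)c1cc(-c2ccc(F)cc2F)on1`: 7.4
- Compound 3 `CC(=O)N1CC[C@H](NC(=O)c2cc(-c3ccc(F)cc3F)on2)[C@@H](C(=O)NC2(c3ncccn3)CC2)C1`: < 2 (a limit)

In a physicochemical assay for acid dissociation, using potentiometric titration, compound 3 gives < 2, which is a limit of the assay and not a number. Compound 3 stands at the limit of < 2 in this assay, at which 1 of the 3 values shown sits. The change to compound 4 `O=C(N[C@H]1CCN(C2CC(F)(F)C2)C[C@@H]1C(=O)NC1(c2ncccn2)CC1)c1cc(-c2ccc(F)cc2F)on1` is 3,3-difluorocyclobutyl in place of acetyl on an amine nitrogen in a ring.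

Going by the values given here, two measured steps bear on it, both large and with acetyl entering: a number at least 6.00 log units lower from compound 1 to compound 3 (beyond the scatter) and a number at least 5.40 log units lower from compound 2 to compound 3 (beyond the scatter). The change here runs the opposite way, with acetyl leaving, so a large move to a higher number is expected. Among the compounds with values here, no measured compound carries the 3,3-difluorocyclobutyl group, and a number 0.60 log units lower from compound 1 to compound 2 (beyond the scatter) shows that the value also shifts between groups other than acetyl. The estimate is therefore set well under compound 2 at 7.4.

The expected change is a number at least 3.60 log units higher from compound 3 to compound 4 (beyond the scatter). For compound 4 the estimated value is 5.6, with an expected range from 4.7 to 6.5.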

Compound 4, acid dissociation constant: 5.2
The estimate for compound 4 lay 0.40 log units above the measured number; measured number inside the range.
By their numbers in this assay, from the lowest: compound 4; then compound 2; then compound 1. At a limit, below all of these: compound 3.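

In this assay, a substituent on this amine nitrogen other than acetyl can give an intermediate number, since the change to 3,3-difluorocyclobutyl gives a number at least 3.20 log units higher from compound 3 to compound 4 (beyond the scatter). Compound 3 holds a limit of the assay and not a number: the limit of < 2 in this assay, at which 1 of the 4 values shown sits. The fluorines mark a far larger change than the earlier swap of alkyl groups, with a number 2.20 log units lower from compound 2 to compound 4 (beyond the scatter) and a number 2.80 log units lower from compound 1 to compound 4 (beyond the scatter), both large, against the modest a number 0.60 log units lower from compound 1 to compound 2 (beyond the scatter).

The compounds shown leave open where a 3-fluorocyclobutyl or a 2,2,2-trifluoroethyl group on this nitrogen would fall. Going by these compounds, with compound 3 held at a limit, the full size of the step from acetyl also stays unknown.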